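Dropping the Hydroxy Group: A Parallel Step Expected

The source may report more compounds than this note shows. Statements on the series, on what has been measured and on what is new or still open speak of the compounds shown alone.

Of the compounds shown here, three sharing a core have been tested in a functional assay on HepG2 cells (Homo sapiens) for inhibition, read by MTT assay, with a stated time of 72 h; on this read-out higher numbers stand for weaker inhibition and lower numbers for stronger inhibition. Compound 1 `Oc1ccc(-c2nnc(SCCCN3CCN(c4nc5ccccc5o4)CC3)o2)cc1` gives 502000 nM in this assay. Compound 2 `c1ccc(-c2nnc(SCCCN3CCN(c4nc5ccccc5o4)CC3)o2)cc1` gives 102000 nM. Compound 3 `Oc1ccc(-c2nnc(SCCCN3CCN(c4nc5ccccc5s4)CC3)o2)cc1` gives 364000 nM, which sits close to compound 1 and well apart from compound 2.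

The change from compound 1 to compound 2 is described here:
hydrogen in place of hydroxy on an aromatic carbon
This change brought a 4.9-fold lower number from compound 1 to compound 2 (0.69 log units; beyond the scatter).

Compound 3 differs from compound 1 in its core, as follows:
1,3-benzothiazol-2-yl in place of 1,3-benzoxazol-2-yl on an amine nitrogen in a ring
That change brought a 1.4-fold lower number from compound 1 to compound 3 (0.14 log units; within the scatter), a step that does not stand out from ordinary repeat variation.

Compound 4 `c1ccc(-c2nnc(SCCCN3CCN(c4nc5ccccc5s4)CC3)o2)cc1` has not yet been measured. It differs from compound 3 in this way:
hydrogen in place of hydroxy on an aromatic carbon
Among the compounds with values here, the place of the change is the same in both pairs, so this is the same kind of change as the one from compound 1 to compound 2, carried out on the other core. Because the earlier change gave a 4.9-fold lower number from compound 1 to compound 2 (0.69 log units; beyond the scatter), and because the two cores sit close together, with a 1.4-fold lower number from compound 1 to compound 3 (0.14 log units; within the scatter), a step of similar size is expected here: the number is expected to fall from compound 3 to compound 4 by a 4.9-fold lower number from compound 3 to compound 4 (0.69 log units; beyond the scatter). Compound 4 is therefore estimated to give 75000 nM in this assay, with a likely range from 30000 nM to 200000 nM. Within the data shown here, this expectation rests on only two compounds with the hydroxy group and one without, so it is tentative.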

Compound 4, half-maximal inhibitory concentration: 217000 nM
Estimate against measurement, compound 4: 2.9-fold (0.46 log units) below, outside the stated range (above it).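

In this assay, taking away the hydroxy group on the second core gave a 1.7-fold lower number from compound 3 to compound 4 (0.22 log units; within the scatter), a step that does not stand out from ordinary repeat variation, so the clear shift seen on the first core did not carry over at its full size: the same change on two cores in this assay, a 4.9-fold lower number (0.69 log units; beyond the scatter) from compound 1 to compound 2 and a 1.7-fold lower number (0.22 log units; within the scatter) from compound 3 to compound 4, 2.9-fold (0.47 log units) apart, beyond the scatter of two such steps. Seen from the other side, the same four compounds show that the swap of 1,3-benzoxazol-2-yl for 1,3-benzothiazol-2-yl, which did not stand out while the hydroxy group was present, gave a 2.1-fold higher number from compound 2 to compound 4 (0.33 log units; beyond the scatter) once it was gone: the same change on two cores in this assay, a 1.4-fold lower number (0.14 log units; within the scatter) from compound 1 to compound 3 and a 2.1-fold higher number (0.33 log units; beyond the scatter) from compound 2 to compound 4, 2.9-fold (0.47 log units) apart, beyond the scatter of two such steps. Together these show that the result of going from 4-hydroxyphenyl to phenyl depended on the core in these four compounds, but they do not show why, do not prove that the change has no effect on the second core, and, with only one pair on each core, give no general rule for the series.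

As far as these compounds go, it remains open whether other groups in place of the hydroxy group, such as a methoxy group, a fluorine atom or an amine, would also respond differently on the two cores. From the compounds shown here alone, it is equally open whether the same difference between the cores would hold with a longer chain.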